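From phenyl to thiophen-2-yl on a shared core

The compounds below may be only part of what the source reports. "The series", "measured", "known", "first", "only" and "open" are said of these compounds alone.

Compound 1 `c1ccc(-c2cc(-c3cccnc3)nc(-c3ccccn3)c2)cc1`: 44.8 ug/mL
Compound 2 `c1ccc(-c2cc(-c3ccoc3)cc(-c3ccccn3)n2)nc1`: 0.08 ug/mL

In a functional assay on A549 cells (Homo sapiens) for antiproliferative activity (a lower number here means a stronger inhibitor of growth, a higher number a weaker inhibitor of growth), compound 1 has the higher of the two numbers, and compound 2 lies far lower, a gap beyond the usual scatter. Compound 3 `c1ccc(-c2cc(-c3cccs3)cc(-c3cccnc3)n2)nc1` has not yet been measured. It carries thiophen-2-yl in place of phenyl on an aromatic carbon, opposite the ring nitrogen of the core of compound 1 (thiophen-2-yl in place of phenyl on an aromatic carbon). Among the measured compounds shown here, no step between measured compounds isolates such a change, so the expectation rests on little. Compound 2 also holds a five-membered aromatic ring and gives 0.08 ug/mL in this comparison, though it differs from compound 1 elsewhere too. A step toward a lower number in this assay is therefore expected, beyond the scatter but far smaller than that gap. The step expected is a 5.6-fold lower number from compound 1 to compound 3 (0.75 log units; beyond the scatter) by this estimate. For compound 3 the expected value is 8 ug/mL (estimated range 0.8 ug/mL to 50 ug/mL).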

Compound 3, concentration for 50% growth inhibition: 78.9 ug/mL
Beside the measured number, compound 3's estimate is 9.9-fold (0.99 log units) below it; measured number above the stated range.
By their numbers in this assay, from the lowest: compound 2; then compounds 1 and 3 (each within the scatter of the next).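

In this assay, placing thiophen-2-yl instead of phenyl on the aromatic carbon opposite the ring nitrogen gives a 1.8-fold higher number from compound 1 to compound 3 (0.25 log units; within the scatter), so this single change, with the pyridin-2-yl and pyridin-3-yl groups kept in place, leaves the number within the scatter. On this core, then, thiophen-2-yl at this position does not by itself bring a low number, something the first pair could not show, as compound 1 and compound 2 differ in more than one place. No measurement available here offers an explanation for this result.

Compound 2 differs from both compound 1 and compound 3 in more than one place, so its value cannot be tied to any single change. As far as these compounds go, it also remains open how this assay would respond to an amine or a carboxylic acid on this same carbon.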